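Adding a Hydroxy Group to a Pyrrolidine Side Chain

The compounds below may be only part of what the source reports. "The series", "measured", "known", "first", "only" and "open" are said of these compounds alone.

Compound 1, `O=C(Nc1ccc(Oc2ccccc2)cc1)Nc1ccc2c(cnn2CCN2CCCCC2)c1`, gives 136 nM.
Compound 2, `O=C(Nc1ccc(Oc2ccccc2)cc1)Nc1ccc2nn(CCN3CCCC3)cc2c1`, gives 314 nM.

Both compounds were measured in a functional assay on IMR-32 cells (Homo sapiens) for inhibition, read by FLIPR and calcium flux; on this read-out higher numbers stand for weaker inhibition and lower numbers for stronger inhibition. Among the compounds with values here, compound 2 holds the highest of the two numbers; the only other compound, compound 1, gives a lower number, and the gap between them lies beyond the usual scatter, so compound 1 is the stronger inhibitor of this pair.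

Compound 3, `O=C(Nc1ccc(Oc2ccccc2)cc1)Nc1ccc2nn(CCN3CC[C@H](O)C3)cc2c1`, has not yet been measured. It differs from compound 2 in one place: hydroxy in place of hydrogen on a saturated ring carbon. Within the data shown here, no measured pair in this set shows this kind of change, so there is nothing to calibrate the step against. The expectation is a step from compound 2 to compound 3 of a 1.1-fold higher number from compound 2 to compound 3 (0.05 log units; within the scatter), that is, no change beyond the scatter. Compound 3 is accordingly expected to give 350 nM, within a range from 130 nM to 950 nM.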

Compound 3, half-maximal inhibitory concentration: 214 nM
Compound 3: middle estimate off by 1.6-fold (0.21 log units), on the high side, and the stated range covers the measured number.
By their numbers in this assay, from the lowest: compounds 1, 3 and 2 (each within the scatter of the next, the first and the last beyond it).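

Putting a hydroxy group on this saturated ring carbon, two ring bonds from the ring nitrogen, gives in this assay a 1.5-fold lower number from compound 2 to compound 3 (0.17 log units; within the scatter). Within the data shown here, this is the first step of its kind in the set, and it shows that the pyrrolidine side chain can carry this added oxygen, with its hydrogen-bond donor and acceptor, without a change in inhibition that stands clear of the scatter. No measurement here offers an explanation for this result.

The compounds shown leave open whether a methoxy group, an amine or a carboxylic acid on this same ring carbon would also leave the number within the scatter. Among these compounds, they also leave open how the mirror-image form of the 3-hydroxypyrrolidin-1-yl group would compare with the one in compound 3.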